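A few compounds are considered here, and "the series" means these few. Any claim that something is new, unique, unknown or untested is made for them only; others in the source may bear on it.

Compound 1 `CC1(C)CC(Oc2ccc(C(=O)Nc3ccc(NC(=O)Nc4cc(C(C)(C)C)on4)cc3)nc2)CC(C)(C)N1`: 11 mL/min/kg
Compound 2 `Cc1ccnc(C(=O)Nc2ccc(NC(=O)Nc3cc(C(C)(C)C)on3)cc2)c1`: 37.9 mL/min/kg

Both were measured in an in vivo ADME assay on the whole organism (plasma, strain Sprague-Dawley) for pharmacokinetics, with Rattus norvegicus as the target, read by LC-MS; a lower number here means slower removal, a higher number faster removal of the compound. Compound 1 gives the lower of the two numbers, and the gap to compound 2 lies beyond the scatter. Compound 3 `CC(C)(C)c1cc(NC(=O)Nc2ccc(NC(=O)c3ccc(OC4CCN(C5CC5)CC4)cn3)cc2)no1` has not yet been measured. It differs from compound 1 in one place: 1-cyclopropylpiperidin-4-yl in place of 2,2,6,6-tetramethylpiperidin-4-yl on an oxygen on an aromatic ring. Within the data shown here, no measured pair shows this exact change, so its effect remains open. The number for compound 3 is expected to be modestly higher than that of compound 1, a step of a 1.8-fold higher number from compound 1 to compound 3 (0.26 log units; within the scatter), not clearly beyond the scatter. The estimate for compound 3 is 20 mL/min/kg, within 8 mL/min/kg to 45 mL/min/kg.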

Compound 3, clearance: 12 mL/min/kg
Compound 3: middle estimate off by 1.7-fold (0.22 log units), on the high side; the range from low to high includes it.
By their numbers in this assay, from the lowest: compounds 1 and 3 (each within the scatter of the next); then compound 2.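

In this assay, placing 1-cyclopropylpiperidin-4-yl in place of 2,2,6,6-tetramethylpiperidin-4-yl on the oxygen gives a 1.1-fold higher number from compound 1 to compound 3 (0.04 log units; within the scatter) and so leaves clearance unchanged within the scatter. At this position, then, the low clearance of compound 1 does not depend on the tetramethyl pattern, and it persists when the ring nitrogen carries a cyclopropyl group and no hydrogen-bond donor. Nothing measured here explains why the two groups read alike.

Open, going by these compounds, is whether a morpholine, a plain methoxy group or a carboxylic acid on this oxygen would hold clearance equally low.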